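Benzyl ether of the phenol in the shared core

The source may report more compounds than this note shows. Statements on the series, on what has been measured and on what is new or still open speak of the compounds shown alone.

Compound 1 `COc1cc2c(c(O)c1OC)C(=O)[C@]1(OC)C=C[C@H]2N(C(=O)OCC(C)C)N1C(=O)OCC(C)C` carries the free hydroxy on the shared core. In an ADME assay on KB cells (Homo sapiens) for cytotoxicity (a lower number here means that less compound is needed, a higher number that more compound is needed for the effect), compound 1 gives > 300 ug/mL, a limit of the assay rather than a number. Compound 4 `COc1cc2c(c(OCc3ccccc3)c1OC)C(=O)[C@]1(OC)C=C[C@H]2N(C(=O)OCC(C)C)N1C(=O)OCC(C)C` differs from compound 1 by benzyl in place of hydrogen on an oxygen on an aromatic ring. Among the measured compounds shown here, no measured step covers this change directly. The nearest comparison involves compound 2 `COC(=O)N1[C@@H]2C=C[C@@](OC)(C(=O)c3c2cc(OC)c(OC)c3OCc2ccc(OC)cc2)N1C(=O)OC` and compound 3 `COC(=O)N1[C@@H]2C=C[C@@](OC)(C(=O)c3c2cc(OC)c(OC)c3OCc2ccccc2F)N1C(=O)OC`. Compound 2 gives > 300 ug/mL, which is a limit of the assay. Compound 3 gives 137 ug/mL. The step of an at least 2.1-fold lower number from compound 2 to compound 3 (0.34 log units; beyond the scatter) shows that a benzyl ether on this oxygen can sit at the limit or modestly below it. Given (the limit of > 300 ug/mL in this assay, at which 2 of the 3 values shown sit), the limit is the more common outcome in this set. The expected step for compound 4 is a number no higher from compound 1 to compound 4 (the limit leaves the size open), most likely none beyond the scatter. Compound 4 is estimated at 300 ug/mL, between 130 ug/mL and 700 ug/mL.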

Compound 4, concentration for half-maximal effect: 94 ug/mL
For compound 4 the middle estimate is 3.2-fold (0.50 log units) above the measured one; measured number below the stated range.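

Hydroxy to benzyloxy on the shared core gives an at least 3.1-fold lower number from compound 1 to compound 4 (0.50 log units; beyond the scatter) in this assay. Unlike the earlier pair, which compared two substituted benzyl ethers, this step compares a benzyl ether directly with the free hydroxy and shows that the ether alone lowers the number. Values at the limit remain frequent in this series: the limit of > 300 ug/mL in this assay, at which 2 of the 4 values shown sit.

Still open, from the compounds shown here alone, is whether a shorter group on this oxygen, such as methyl, or a benzyl carrying an amine, would lower the number further. Also open, going by these compounds, is whether the same step holds on the core of compound 2.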